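A pyrazole replaces the formylthiophene

The source may report more compounds than this note shows. Statements on the series, on what has been measured and on what is new or still open speak of the compounds shown alone.

Values in a functional assay on MV4-11 cells (Homo sapiens) for inhibition, read by resazurin assay, with a stated time of 72 h; on this read-out higher numbers stand for weaker inhibition of growth and lower numbers for stronger inhibition of growth
Compound 1 `O=C1NCCC12CCN(c1c(Cl)cncc1-c1ccc(Cl)s1)CC2` gives 560 nM
Compound 2 `O=Cc1cscc1-c1cncc(Cl)c1N1CCC2(CCNC2=O)CC1` gives 27100 nM

Of these two, compound 2 with 27100 nM stands highest. The change to compound 3 `O=C1NCCC12CCN(c1c(Cl)cncc1-c1cn[nH]c1)CC2` is 1H-pyrazol-4-yl in place of 4-formylthiophen-3-yl on an aromatic carbon and puts 1H-pyrazol-4-yl in place of 4-formylthiophen-3-yl on an aromatic carbon. Going by the values given here, the only measured step at this place is a 48-fold higher number from compound 1 to compound 2 (1.68 log units; beyond the scatter) and it brought in the 4-formylthiophen-3-yl that now leaves. As far as these compounds go, a clear step towards a lower number is therefore expected in this assay although 1H-pyrazol-4-yl itself is untested. The expected change is a 6.8-fold lower number from compound 2 to compound 3 (0.83 log units; beyond the scatter) on this reasoning. For compound 3 the estimate is 4000 nM with an expected range of 600 nM to 25000 nM in this read-out.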

Compound 3, concentration for 50% growth inhibition: 8520 nM
Compound 3: middle estimate off by 2.1-fold (0.33 log units), on the low side; measured number inside the range.
By their numbers in this assay, from the lowest: compound 1; then compound 3; then compound 2.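

In this assay the 1H-pyrazol-4-yl recovers only part of the loss seen with the 4-formylthiophen-3-yl (a 3.2-fold lower number from compound 2 to compound 3 (0.50 log units; beyond the scatter)), and it still falls well short of the 5-chlorothiophen-2-yl (a 15-fold higher number from compound 1 to compound 3 (1.18 log units; beyond the scatter)). Among these three groups on this aromatic carbon, the 5-chlorothiophen-2-yl therefore gives the lowest number, so a second five-membered aromatic ring alone does not restore that level. Nothing measured here explains the differences. The compounds shown leave open whether the gain comes from the chloro group or from the thiophene itself. They also leave open how a plain thiophen-2-yl or a phenyl ring would read at this position.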